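A few compounds are considered here, and "the series" means these few. Any claim that something is new, unique, unknown or untested is made for them only; others in the source may bear on it.

Compound 1 `CCCC(=O)C1=C(C)NC(=O)NC1c1ccco1` gives 1% in an assay on membranes from HeLa cells for displacement of a labelled ligand from adenosine receptor A3 (Homo sapiens), read by scintillation counting, with a stated time of 180 min, tested at 1 uM (a higher number here means more inhibition at the concentration tested (going by the name of the read-out), a lower number less inhibition), the lowest of the three numbers shown, though the steps to both other compounds lie within the scatter. Compound 2 `CCCC(=O)C1=C(C)NC(=O)NC1c1cccs1` gives 2%, and compound 3 `CC1=C(c2ncc(C)o2)C(c2ccco2)NC(=O)N1` gives 4%; the steps of a number 1 percentage points higher from compound 1 to compound 2 (within the scatter) and a number 3 percentage points higher from compound 1 to compound 3 (within the scatter) are both within the scatter. Compound 4 `CCC(C)OC(=O)C1=C(C)NC(=O)NC1c1ccco1` differs from compound 1 by sec-butoxy in place of propyl on a carbonyl carbon. Neither measured step concerns the carbonyl carbon, so none bears directly on this change; both, however, show that changes at two other places left the inhibition essentially unmoved. The inhibition of compound 4 is therefore expected to show no step beyond the scatter from compound 1, a number 1 percentage points higher from compound 1 to compound 4 (within the scatter). The estimate for compound 4 is 2%, with a range from 0% to 12%.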

Compound 4, a percentage reported as inhibition, at one concentration (the size of the read-out at that concentration, not a potency): 3%
Estimate against measurement, compound 4: 1 percentage points below, within the range that was stated.
By their numbers in this assay, from the lowest: compounds 1, 2, 4 and 3 (each within the scatter of the next).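

Replacing propyl with sec-butoxy on a carbonyl carbon gives a number 2 percentage points higher from compound 1 to compound 4 (within the scatter) in this assay. Among the compounds shown here, the carbonyl position, which the earlier steps did not touch, thus joins the two other varied places in showing no step beyond the scatter, even with the added oxygen of the sec-butoxy group. Nothing available explains this result.

Going by these compounds, it remains open whether an amine, a carboxylic acid or a longer chain on this carbonyl carbon would move the inhibition beyond the scatter. Also open, on these data alone, is whether sec-butoxy would behave alike with thiophen-2-yl in place of furan-2-yl.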